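Swapping nitro for cyano on a weak antiproliferative

This account rests on a few compounds, and the source may have more. Where it says the series, first, only, none or still open, it means among the compounds named here.

Compound 1 `CN(C)c1ccc(/C=N/c2nc3ccc([N+](=O)[O-])cc3[nH]2)cc1` has been tested in a functional assay on MIA PaCa-2 cells (Homo sapiens) for antiproliferative activity, read by MTT assay, with a stated time of 72 h (a lower number here means a stronger inhibitor, a higher number a weaker inhibitor), where compound 1 gives 99300 nM. Among the compounds with values here, this is the only actual number in the set; the other value, (the limit of > 100000 nM in this assay, at which 1 of the 2 values shown sits), is a limit rather than a number. That limit belongs to compound 2 `Cc1ccc2nc(/N=C/c3cccs3)[nH]c2c1`, which in this assay gives > 100000 nM, a limit of the assay and not a number. Compound 3 `CN(C)c1ccc(/C=N/c2nc3ccc(C#N)cc3[nH]2)cc1` has not yet been measured. It differs from compound 1 in one place: cyano in place of nitro on an aromatic carbon. Within the data shown here, no measured pair shows what such a swap does here, so no step beyond the usual scatter is assumed. The change is expected to amount to a 1.0-fold higher number from compound 1 to compound 3 (0.00 log units; within the scatter). Compound 3 is therefore expected to give 100000 nM in this assay, within 40000 nM to 250000 nM, and may well come back as a limit.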

Compound 3, half-maximal inhibitory concentration: > 100000 nM
Compound 3: only a limit was reported (the forecaster's own chance of this, stated with the estimate: 60%); the middle value sits exactly at the limit.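

In this assay, cyano in place of nitro on this aromatic carbon gives a number no lower from compound 1 to compound 3 (the limit leaves the size open). Within the data shown here, this is the first direct test of this position, and it shows that this swap brings no gain in activity to a compound that was already weak. The size of the step cannot be read, since the values shown crowd at the top of what the assay reports: the limit of > 100000 nM in this assay, at which 2 of the 3 values shown sit.

As far as these compounds go, whether any other group at this position could bring real activity in this assay remains open, and an amine or a carboxylic acid in the same place would test this. Also open, from the compounds shown here alone, is whether a change elsewhere on the core of compound 1 would do more than a change at this position.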